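Working notes on the aryl urea series, step one to four

A few compounds are considered here, and "the series" means these few. Any claim that something is new, unique, unknown or untested is made for them only; others in the source may bear on it.

Compound 1 `COc1cc(NC(C)CCCNC(=O)Nc2cccc(Cl)c2)c2ncccc2c1` — 11000 nM in a functional assay on MCF7 cells (Homo sapiens) for inhibition, read by MTT assay, with a stated time of 72 h; a higher number here means a weaker inhibitor, a lower number a stronger inhibitor
Compound 2 `COc1cc(NC(C)CCCNC(=O)Nc2ccc(C(F)(F)F)cc2)c2ncccc2c1` — 1900 nM
Compound 3 `COc1cc(NC(C)CCCNC(=O)NNC(=O)Nc2cccc(Cl)c2)c2ncccc2c1` — 220 nM

Compound 1 has the highest number of the three measured and is the weakest inhibitor among them: a 5.8-fold lower number from compound 1 to compound 2 (0.76 log units; beyond the scatter) and a 50-fold lower number from compound 1 to compound 3 (1.70 log units; beyond the scatter), both beyond the scatter.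

Compound 4 `COc1cc(NC(C)CCCNC(=O)NNC(=O)Nc2ccc(O)cc2)c2ncccc2c1` is not yet measured. It differs from compound 1 in one place: ((4-hydroxyphenyl)carbamoyl)amino in place of 3-chlorophenyl on an amide-type nitrogen.

The step that bears most directly on this is a 50-fold lower number from compound 1 to compound 3 (1.70 log units; beyond the scatter), where the same insertion of a carbamoylamino link was made while the 3-chlorophenyl stayed; that step was large. Within the data shown here, compound 4 instead carries a 4-hydroxyphenyl on the inserted group, and no measured pair isolates that exchange; compounds 3 and 4 differ only there, and compound 3 stands at 220 nM. A change of the aryl substituent alone has shifted the number before, modestly (a 5.8-fold lower number from compound 1 to compound 2 (0.76 log units; beyond the scatter)), so the hydroxyl variant adds uncertainty around the large gain seen for the insertion.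

The expected step in this assay is therefore a large fall, estimated as a 28-fold lower number from compound 1 to compound 4 (1.44 log units; beyond the scatter). Compound 4 is estimated at 400 nM, with a range from 100 nM to 1600 nM.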

Compound 4, half-maximal inhibitory concentration: 2600 nM
For compound 4 the middle estimate is 6.5-fold (0.81 log units) below the measured one, and the stated range ends below it.
By their numbers in this assay, from the lowest: compound 3; then compounds 2 and 4 (each within the scatter of the next); then compound 1.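

In this assay, the gain from the inserted carbamoylamino link depends on the aryl group it carries: with the link held in place, the exchange of 3-chlorophenyl for 4-hydroxyphenyl gives a 12-fold higher number from compound 3 to compound 4 (1.07 log units; beyond the scatter), which undoes much of a 50-fold lower number from compound 1 to compound 3 (1.70 log units; beyond the scatter). What survives of the combined change is only a 4.2-fold lower number from compound 1 to compound 4 (0.63 log units; beyond the scatter), and a 1.4-fold higher number from compound 2 to compound 4 (0.14 log units; within the scatter) leaves compound 4 not separated from compound 2, which has no inserted link, so the link alone does not secure a low number. Nothing at hand accounts for the difference between the two aryl groups on the link.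

The compounds shown leave open whether the loss follows the hydroxyl group itself or the move from the substitution of 3-chlorophenyl to that of 4-hydroxyphenyl; a 4-chlorophenyl or a 3-hydroxyphenyl on the inserted link would separate the two. Also open, as far as these compounds go, is whether 4-(trifluoromethyl)phenyl, which gave a 5.8-fold lower number from compound 1 to compound 2 (0.76 log units; beyond the scatter) on the plain urea, keeps that advantage on the inserted link, and how a ring carrying an amine or a carboxylic acid would fare there.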